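The compounds below may be only part of what the source reports. "The series", "measured", "known", "first", "only" and "open" are said of these compounds alone.

Working notes on the series, read-out from a physicochemical assay for acid dissociation. Among the compounds with values here, only two numbers are in hand so far. Compound 1 (`CN(Cc1ccccc1)Cc1ccc(CNc2ccnc3cc(Cl)ccc23)cc1`) gives 9.9, and compound 2 (`CN(Cc1ccc(N(C)C)cc1)Cc1ccccc1CNc1ccnc2cc(Cl)ccc12`) gives 9.71. These two values lie within the scatter of each other, so compound 1 stands level with compound 2 and does not separate from it on this read-out.

Compound 3 (`CN(Cc1ccc(CNc2ccnc3cc(Cl)ccc23)cc1)Cc1ccc(N(C)C)cc1`) has not yet been measured in this assay. It derives from compound 1 by one change: dimethylamino in place of hydrogen on an aromatic carbon, para to a large group (dimethylamino in place of hydrogen on an aromatic carbon).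

Within the data shown here, no measured pair differs in one place only, so the size of this step has no direct precedent. Compound 2 also carries a dimethylamino group and gives 9.71, which offers no sign of a shift away from compound 1. The expected change is therefore none beyond the scatter, with at most a slight drift to a lower number, and the estimated step is a number 0.10 log units lower from compound 1 to compound 3 (within the scatter). The estimate for compound 3 is 9.8, with an expected range from 9.4 to 10.2.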

Compound 3, acid dissociation constant: 9.66
Beside the measured number, compound 3's estimate is 0.14 log units above it, and the stated range covers the measured number.
By their numbers in this assay, from the lowest: compounds 3, 2 and 1 (each within the scatter of the next).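

In this assay the series now has its first pair that differs in one place, and dimethylamino in place of hydrogen on an aromatic carbon, para to a large group, reads as a number 0.24 log units lower from compound 1 to compound 3 (within the scatter) and so does not separate the two compounds. Compound 2 could not show this, as it differs from compound 1 in more than one place, whereas the change from phenyl to 4-(dimethylamino)phenyl is now read on its own, and at this position these three added heavy atoms leave the number within the scatter. No measurement in hand bears on what lies behind this result.

The compounds shown leave open whether another group at this same position, such as a carboxylic acid, a primary amine or a longer chain ending in an amine, would move the number beyond the scatter of compound 1. They also leave open which site in these molecules gives up the proton that this number reports, and whether dimethylamino placed elsewhere on the same ring would read the same way.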